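The source may hold more compounds than are shown below. What is called first, only, known or untested is meant among the compounds shown, and "the series" means these compounds.

Measured compounds:
- compound 1, `O=C(O)c1cnc2cc(F)ccc2c1O`: 501000 nM
- compound 2, `COc1ccc2c(O)c(C(=O)O)cnc2c1`: 525000 nM
- compound 3, `O=C(O)c1cnc2cc(O)ccc2c1O`: 912000 nM

All three values come from a functional assay on Ehrlich cells (Mus musculus) for inhibition; on this read-out higher numbers stand for weaker inhibition and lower numbers for stronger inhibition. Compound 3 gives the highest of the three numbers, but the separations are small: a 1.7-fold higher number from compound 2 to compound 3 (0.24 log units; within the scatter) and a 1.8-fold higher number from compound 1 to compound 3 (0.26 log units; within the scatter), both within the scatter. The third comparison, a 1.0-fold higher number from compound 1 to compound 2 (0.02 log units; within the scatter), is likewise within the scatter. Every measured step is a change of the substituent on an aromatic carbon of the shared core, and none of them moved the read-out beyond noise.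

Compound 4, `NC(=O)c1ccc2c(O)c(C(=O)O)cnc2c1`, differs from compound 3 by carbamoyl in place of hydroxy on an aromatic carbon. This is again a change at an aromatic carbon of the carbocyclic ring of the core, the same kind of change as the three measured steps. On that basis no step beyond the scatter is expected, neither upward nor downward, and the estimated step is a 1.1-fold lower number from compound 3 to compound 4 (0.06 log units; within the scatter). Compound 4 is therefore expected to give about 800000 nM, with a likely range from 300000 nM to 2000000 nM in this assay.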

Compound 4, half-maximal inhibitory concentration: 5750000 nM
The estimate for compound 4 lay 7.2-fold (0.86 log units) below the measured number; the whole stated range lies below it.
By their numbers in this assay, from the lowest: compounds 1, 2 and 3 (each within the scatter of the next); then compound 4.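

In this assay, within the data shown here, this position is not indifferent to the substituent: fluoro, methoxy and hydroxy gave numbers within the scatter of one another, whereas carbamoyl is the first group here to shift the read-out beyond it, toward weaker inhibition. The shift appears against all three earlier groups, with a 6.3-fold higher number from compound 3 to compound 4 (0.80 log units; beyond the scatter) against hydroxy, an 11-fold higher number from compound 2 to compound 4 (1.04 log units; beyond the scatter) against methoxy and an 11-fold higher number from compound 1 to compound 4 (1.06 log units; beyond the scatter) against fluoro. Hydroxy and carbamoyl each count 1 hydrogen-bond donor and 1 hydrogen-bond acceptor, so those counts do not separate them, and no measurement offered here accounts for the shift.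

Still open, from the compounds shown here alone, is whether the shift belongs to carbamoyl alone or extends to other groups at this carbon, such as a carboxylic acid, a nitrile or a methyl amide. Also open, going by these compounds, is whether carbamoyl would behave the same way on another aromatic carbon of the shared core.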